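Chloro for ethyl on the shared core: stability note

The source may report more compounds than this note shows. Statements on the series, on what has been measured and on what is new or still open speak of the compounds shown alone.

Measured so far in an in vitro ADME assay on microsomes (Rattus norvegicus) for metabolic stability; a lower number here means that the compound disappears faster, a higher number that the compound lasts longer:
- compound 1 `CCc1nc(-c2ccc(Cl)cc2Cl)c(CC)nc1NC(CC)CC` gives 0.07 h
- compound 2 `CCCN(CC1CC1)c1nc(CC)c(-c2ccc(Cl)cc2Cl)nc1CC` gives 0.07 h
- compound 3 `CCc1nc(-c2ccc(Cl)cc2Cl)c(CC)nc1CC(CC)CC` gives 0.0417 h

Compound 1 stands level with compound 2 at the digits printed, the two together being the highest of the three numbers: no change at the digits printed from compound 1 to compound 2 (within the scatter). The furthest of the three from compound 1 is compound 3, yet a 1.7-fold lower number from compound 1 to compound 3 (0.22 log units; within the scatter), and likewise a 1.7-fold lower number from compound 2 to compound 3 (0.22 log units; within the scatter). Within these three the numbers are all of one kind, with nothing beyond the scatter.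

Compound 4 `CCc1nc(NC(CC)CC)c(Cl)nc1-c1ccc(Cl)cc1Cl` has not yet been run in this assay. Against compound 1 the difference is chloro in place of ethyl on an aromatic carbon. Among the compounds with values here, none of the measured steps touches this position: each of them replaces the (pentan-3-yl)amino or (cyclopropylmethyl)(propyl)amino group, and all stayed within the scatter. Within the data shown here, no measured step therefore bears on the change to compound 4, and the expectation is no step beyond the scatter, no change at the digits printed from compound 1 to compound 4 (within the scatter). Compound 4 is estimated at 0.07 h, with a range from 0.035 h to 0.14 h.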

Compound 4, half-life: < 0.0167 h
Compound 4 gave a limit, no number (the forecaster's own chance of this, stated with the estimate: 10%); at least 4.1-fold (0.62 log units) between middle value and limit.
By their numbers in this assay, from the lowest: compounds 3, 1 and 2 (each within the scatter of the next). At a limit, below all of these: compound 4.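

Chloro in place of ethyl, on the aromatic carbon ortho to the (pentan-3-yl)amino group, gives an at least 4.1-fold lower number from compound 1 to compound 4 (0.62 log units; beyond the scatter) in this assay, the first step in the series beyond the scatter. The steps among compounds 1, 2 and 3, all at the (pentan-3-yl)amino place, stayed within the scatter, and this position is the one place shown where a single change reaches beyond it. On these data alone, compound 4 gives a limit and not a number, and the full size of the step stays unknown because the read-out ends there: the limit of < 0.0167 h in this assay, at which 1 of the 4 values shown sits.

Open, as far as these compounds go, is whether methyl, methoxy or a nitrile at this position would stay with compound 1 or go with compound 4. Also open, from the compounds shown here alone, is whether chloro acts alike with (cyclopropylmethyl)(propyl)amino or 2-ethylbutyl in place of (pentan-3-yl)amino.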